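This account rests on a few compounds, and the source may have more. Where it says the series, first, only, none or still open, it means among the compounds named here.

Of the compounds shown here, two have so far been tested in an in vitro functional assay on cells (Fibroblast) for agonist activity at Alpha-1B adrenergic receptor (Homo sapiens) (on this read-out lower numbers stand for an effect already at smaller amounts and higher numbers for an effect only at larger amounts of compound), and both results are limits rather than numbers. Compound 1 `Cc1n[nH]c(-c2ccccc2NCC2=NCCN2)n1` gives < 5020 nM, which is a limit. Compound 2 `Cn1nccc1-c1ccccc1NCC1=NCCN1` gives < 100000 nM, again a limit. Between them lies one structural step, a step that the two limits leave unreadable from compound 1 to compound 2, whose size and direction the two limits leave unreadable. For compound 2, therefore, nothing more is known than that its result sits at the limit described by the limit of < 100000 nM in this assay, at which 1 of the 2 values shown sits, while the other limit in the set is described by the limit of < 5020 nM in this assay, at which 1 of the 2 values shown sits.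

Compound 3 `Cn1ccc(-c2ccccc2NCC2=NCCN2)n1` is the next compound. It differs from compound 2 by 1-methyl-1H-pyrazol-3-yl in place of 1-methyl-1H-pyrazol-5-yl on an aromatic carbon; the two have the same atoms, joined differently. Within the data shown here, the only measured step that bears on this kind of change is a step that the two limits leave unreadable from compound 1 to compound 2, and since it is unreadable, it offers no guidance on size or direction. The step that the limit leaves unreadable from compound 2 to compound 3 is therefore expected to show no change beyond the scatter. The value of compound 3 is expected to be 10000 nM, within a range from 1000 nM to 100000 nM, and a further limit rather than a number is the likeliest outcome.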

Compound 3, half-maximal effective concentration: 50.1 nM
Compound 3: the middle estimate sits 200-fold (2.30 log units) above what was measured; the whole stated range lies above it.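

The steps from compound 1 to compound 3 and from compound 2 to compound 3 cannot be read: the results for compound 1 and compound 2 are limits, not numbers. Left open is whether, and by how much, 1-methyl-1H-pyrazol-3-yl in place of either other group alters the result in this assay.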